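The source may report more compounds than this note shows. Statements on the series, on what has been measured and on what is new or still open speak of the compounds shown alone.

Working notes on the series, with every number taken from a physicochemical assay for solubility, with a stated time of 24 h, tested at 30 mg/mL (on this read-out higher numbers stand for higher solubility and lower numbers for lower solubility), as the single read-out. Compound 1 `CC(=O)N1CC2(C1)CC(NS(=O)(=O)c1ccc(OCc3cc(C)nc4ccccc34)cc1)(C(=O)NO)C2` reads 17000000 nM in this measurement. Compound 2 `Cc1cc(COc2ccc(S(=O)(=O)NC3(CC(=O)NO)CC3)cc2)c2ccccc2n1` reads 1600000 nM in this measurement. Compound 3 `Cc1cc(COc2ccc(S(=O)(=O)NC3(CC(=O)NO)CN(C(=O)CC(C)C)C3)cc2)c2ccccc2n1` reads 900000 nM in this measurement, which places it within the scatter of compound 2 and beyond the scatter on the low side of compound 1.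

The next entry is compound 4 `Cc1cc(COc2ccc(S(=O)(=O)NC3(CC(=O)NO)CN(CCC(F)(F)F)C3)cc2)c2ccccc2n1`, which differs from compound 3 in one place: 3,3,3-trifluoropropyl in place of isobutylcarbonyl on an amine nitrogen in a ring. For the measured compounds named here, no pair of measured compounds isolates a change at this nitrogen, so the series offers no direct step to lean on, and the expectation stays uncertain. Starting from compound 3 at 900000 nM as the anchor, no step beyond the scatter is expected in this assay in either direction, and the range is kept wide to reflect the thin data. The expected change in this estimate is a 1.2-fold higher number from compound 3 to compound 4 (0.09 log units; within the scatter) and no larger trend is assumed. For compound 4 the estimated value is 1100000 nM with an expected range from 300000 nM to 5000000 nM in this read-out.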

Compound 4, solubility: 3400000 nM
For compound 4 the middle estimate is 3.1-fold (0.49 log units) below the measured one; measured number inside the range.
By their numbers in this assay, from the lowest: compounds 3 and 2 (each within the scatter of the next); then compound 4; then compound 1.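

In this assay, for the compounds shown here, the change on the amine nitrogen in the four-membered ring, 3,3,3-trifluoropropyl in place of isobutylcarbonyl, gives a 3.8-fold higher number from compound 3 to compound 4 (0.58 log units; beyond the scatter) and is the first step that isolates this position, showing that a change of this group alone can move the read-out beyond the scatter. The two groups match in heavy-atom count, and neither has a ring or a hydrogen-bond donor, so the step comes with a change in the kind of atoms rather than in those counts: the carbonyl oxygen and its double bond leave, and three fluorines enter. Going by these compounds alone, no measurement on these compounds ties the step to either part of that exchange, so its origin stays unassigned.

The compounds shown leave open whether the step follows the loss of the carbonyl or the arrival of the fluorines, a question that a plain propyl chain on the same nitrogen would separate. Also open, going by these compounds, is how a longer chain, an amine or a carboxylic acid at this nitrogen would read, and whether the same exchange carries the same step on the core of compound 1.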